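Methoxy to Ethoxy on an Anilide Nitrogen Aryl Ring

The source may hold more compounds than are shown below. What is called first, only, known or untested is meant among the compounds shown, and "the series" means these compounds.

Compound 1, `Cc1ccc(-c2nn(-c3ccccc3)cc2C(=O)Nc2ccccc2)cc1`: 2450 nM
Compound 2, `COc1ccc(NC(=O)c2cn(-c3ccccc3)nc2-c2ccc(C)cc2)cc1`: 1620 nM

Of the compounds shown here, two sharing the same core have been measured in a functional assay on MCF7 cells (Homo sapiens) for cytotoxicity, read by MTT assay, with a stated time of 48 h; a higher number here means a weaker inhibitor, a lower number a stronger inhibitor. Compound 1 gives 2450 nM, and compound 2 gives 1620 nM. Going by the values given here, the only step between them, a 1.5-fold lower number from compound 1 to compound 2 (0.18 log units; within the scatter), is methoxy in place of hydrogen on an aromatic carbon, so the two values cannot be told apart; compound 2 merely carries the lowest of the two numbers, with compound 1 a short distance away.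

Compound 3, `CCOc1ccc(NC(=O)c2cn(-c3ccccc3)nc2-c2ccc(C)cc2)cc1`, is not yet measured. It differs from compound 2 by methyl in place of hydrogen on a saturated chain carbon bound to an oxygen on an aromatic ring; cut one bond further out, the change reads methyl to ethyl, methoxy to ethoxy, 4-methoxyphenyl to 4-ethoxyphenyl. Among the compounds with values here, no measured step touches this chain carbon. Within the data shown here, the single step in hand, a 1.5-fold lower number from compound 1 to compound 2 (0.18 log units; within the scatter), concerns the neighbouring oxygen substituent and fell within the scatter, which gives no reason to expect a move in either direction.

The expected step in this assay, a 1.0-fold higher number from compound 2 to compound 3 (0.02 log units; within the scatter), is therefore none beyond the scatter. Compound 3 is estimated at 1700 nM, within a range from 700 nM to 4000 nM.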

Compound 3, half-maximal inhibitory concentration: 1030 nM
Compound 3: the middle estimate sits 1.7-fold (0.22 log units) above what was measured; measured number inside the range.
By their numbers in this assay, from the lowest: compounds 3, 2 and 1 (each within the scatter of the next, the first and the last beyond it).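

In this assay, the step on this saturated chain carbon bound to an oxygen on an aromatic ring, methyl in place of hydrogen, is a 1.6-fold lower number from compound 2 to compound 3 (0.20 log units; within the scatter) and so does not separate methoxy from ethoxy. Going by these compounds alone, the comparison with the hydrogen of compound 1 adds something that the earlier pair did not show: ethoxy in place of that hydrogen gives a 2.4-fold lower number from compound 1 to compound 3 (0.38 log units; beyond the scatter) and is the first step in this small set to pass beyond the scatter, if only modestly, whereas methoxy in place of the same hydrogen gave a 1.5-fold lower number from compound 1 to compound 2 (0.18 log units; within the scatter) and stayed within it. The compounds shown carry no measurement that could account for either step.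

Going by these compounds, it remains open whether a longer chain on this oxygen, such as propoxy or butoxy, would take the number further from that of compound 1 or bring it back. The compounds also leave open whether the oxygen itself matters, which an amine or a plain ethyl group in its place could test.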